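Acetate to Hydroxy at a Shared Cytotoxicity Limit

This account rests on a few compounds, and the source may have more. Where it says the series, first, only, none or still open, it means among the compounds named here.

Measured compounds:
compound 1, `CC(=O)O[C@@H]1CC(C)=C(CCC2=CC(=O)OC2)[C@@]2(C)CCCC(C)(C)[C@H]12`: < 5 ug/mL
compound 2, `CC(=O)O[C@@H]1C[C@@H](C)[C@](O)(CCC2=CC(=O)OC2)[C@@]2(C)CCCC(C)(C)[C@H]12`: < 5 ug/mL

In a functional assay on ZR-75-30 cells (Homo sapiens) for cytotoxicity, read by MTT assay, with a stated time of 72 h (a lower number here means a stronger inhibitor, a higher number a weaker inhibitor), compound 1 gives < 5 ug/mL, which is a limit of the assay rather than a number. In this assay compound 2 likewise gives < 5 ug/mL, again only a limit. Compound 2 therefore stands at the limit of < 5 ug/mL in this assay, at which 2 of the 2 values shown sit, and nothing in the numbers shown separates it from compound 1.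

Compound 3, `C[C@@H]1C[C@@H](O)[C@H]2C(C)(C)CCC[C@]2(C)[C@@]1(O)CCC1=CC(=O)OC1`, has not yet been measured in this assay. It differs from compound 2 in one place: hydrogen in place of acetyl on an oxygen on a saturated carbon. Among the compounds with values here, no step between measured compounds is recorded, so the effect of this change rests on expectation alone. The expected step is a step that the limit leaves unreadable from compound 2 to compound 3, small and within the scatter, in no particular direction. Compound 3 is estimated to give 3 ug/mL in this assay, with a range from 1 ug/mL to 9 ug/mL, and a fair chance that only a limit is reported once more.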

Compound 3, half-maximal inhibitory concentration: < 5 ug/mL
Compound 3: a limit, no number (the forecaster's own chance of this, stated with the estimate: 50%); the middle value is on the limit's open side.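

In this assay compound 3 gives < 5 ug/mL as a limit and not a number. No step can be read between compound 2 and compound 3: the limit of < 5 ug/mL in this assay, at which 3 of the 3 values shown sit. The compounds shown leave open how strong each one actually is, and whether going from acetoxy to hydroxy changes cytotoxicity at all.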